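Chain lengthening on a shared core: compound 2 to compound 3

This account rests on a few compounds, and the source may have more. Where it says the series, first, only, none or still open, it means among the compounds named here.

Measured so far:
- compound 1, `NCCCc1c[nH]c2c(F)cccc12`: 26 nM in an assay on isolated protein for inhibition of Myeloperoxidase (Homo sapiens), read by ELISA, with a stated time of 5 min; a higher number here means a weaker inhibitor, a lower number a stronger inhibitor
- compound 2, `NCCCCc1c[nH]c2c(F)cccc12`: 21 nM in this assay

For the measured compounds named here, compound 2 stands beside compound 1 on these two numbers; the only step available, a 1.2-fold lower number from compound 1 to compound 2 (0.09 log units; within the scatter), does not separate them. Compound 3, `NCCSCCCc1c[nH]c2c(F)cccc12`, is not yet measured in this assay. It differs from compound 2 by (2-aminoethyl)sulfanyl in place of aminomethyl on a saturated chain carbon, three bonds along the chain from an aromatic carbon. Going by the values given here, the one measured step that bears on this change is the chain lengthening from compound 1 to compound 2, which was within the scatter; compound 3 lengthens the same chain again and inserts a sulfur, a change without precedent. No step beyond the scatter is therefore expected in this assay, in either direction. The expected step is a 1.0-fold higher number from compound 2 to compound 3 (0.02 log units; within the scatter). Compound 3 is estimated at 22 nM, with a range of 8 nM to 65 nM.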

Compound 3, half-maximal inhibitory concentration: > 100 nM
Compound 3: a limit, no number (the forecaster's own chance of this, stated with the estimate: 3%); middle value at least 4.5-fold (0.65 log units) away from the limit.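

In this assay compound 3 gives > 100 nM, which is a limit of the assay and not a number. The chain position, three bonds along the chain from an aromatic carbon, now proves sensitive to what it carries: (2-aminoethyl)sulfanyl in place of aminomethyl gives an at least 4.7-fold higher number from compound 2 to compound 3 (0.67 log units; beyond the scatter), and (2-aminoethyl)sulfanyl in place of amino gives an at least 3.8-fold higher number from compound 1 to compound 3 (0.58 log units; beyond the scatter), whereas the earlier change of amino to aminomethyl gave only a 1.2-fold lower number from compound 1 to compound 2 (0.09 log units; within the scatter). The series therefore accepts amino and aminomethyl alike at this position, but not this longer sulfur-containing group, and the true size of the loss has no upper bound here.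

The compounds shown leave open whether the sulfur or the added length accounts for the step. An all-carbon chain of matching length, or an ether oxygen in place of the sulfur, lies outside them.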